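Methoxy additions in a series held at the assay limit

The compounds below may be only part of what the source reports. "The series", "measured", "known", "first", "only" and "open" are said of these compounds alone.

Measured compounds:
compound 1 `COc1ccc(CS(=O)(=O)/C=C/c2ccc(OC)c(OC)c2)cc1` — > 20000 nM
compound 2 `COc1ccc(CS(=O)(=O)/C=C/c2ccc(OC)cc2OC)cc1` — > 20000 nM
compound 3 `COc1ccc(CS(=O)(=O)/C=C/c2cc(OC)c(OC)cc2OC)cc1` — > 20000 nM

In a functional assay on DLD-1 cells (Homo sapiens) for antiproliferative activity, read by trypan blue exclusion (a higher number here means a weaker inhibitor, a lower number a stronger inhibitor), compound 1 gives > 20000 nM, which is a limit of the assay and not a number. In this assay compound 2 likewise gives > 20000 nM, a limit. In this assay compound 3 gives > 20000 nM, again a limit. Compound 2 therefore stands only on a limit, and the two further values shown are limits too; all three sit at the limit of > 20000 nM in this assay, at which 3 of the 3 values shown sit.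

Two measured steps are methoxy in place of hydrogen on an aromatic carbon: a step that the two limits leave unreadable from compound 1 to compound 3 and a step that the two limits leave unreadable from compound 2 to compound 3. From the compounds shown here alone, both are left unreadable by the two limits, so their size is unknown.

Compound 4 `COc1ccc(CS(=O)(=O)/C=C/c2ccc(OC)c(OC)c2OC)cc1` differs from compound 2 by methoxy in place of hydrogen on an aromatic carbon. The same kind of change, made twice before, gave no readable step, so no step beyond the scatter can be expected in this assay in either direction, and the expected outcome is another limit. The expected step from compound 2 to compound 4 is a number no higher from compound 2 to compound 4 (the limit leaves the size open). For compound 4 the estimate is 20000 nM, with a range from 10000 nM to 60000 nM.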

Compound 4, half-maximal inhibitory concentration: > 20000 nM
Compound 4 was reported as a limit; the forecaster's own chance of this, stated with the estimate: 80%; the middle value lies on the limit itself.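

No new step can be read: the steps to compound 4 from compound 1 and compound 2 are both left unreadable by limits of the assay: the limit of > 20000 nM in this assay, at which 4 of the 4 values shown sit.

The compounds shown leave open the size and direction of any methoxy step in this assay.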